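The source may hold more compounds than are shown below. What is called first, only, known or untested is meant among the compounds shown, and "the series" means these compounds.

Measured compounds so far:
compound 1, `CC(C)(C)OC(=O)NCCOc1cc(NC(=O)c2cnccn2)c2ncccc2c1`; in a functional assay on MIA PaCa-2 cells (Homo sapiens) for inhibition, read by MTT assay, with a stated time of 72 h (on this read-out higher numbers stand for weaker inhibition and lower numbers for stronger inhibition), compound 1 gives 870 nM.
compound 3, `Cc1cnc(C(=O)Nc2cc(OCCNC(=O)OC(C)(C)C)cc3cccnc23)cn1`; in this assay compound 3 gives 670 nM.
compound 2, `NCCOc1cc(NC(=O)c2cnccn2)c2ncccc2c1`; for compound 2 this assay reports only a limit, > 10000 nM, and not a number, namely (the limit of > 10000 nM in this assay, at which 1 of the 3 values shown sits).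

Compound 1 and compound 3 share one core and differ only by methyl in place of hydrogen on an aromatic carbon, a change that gave a 1.3-fold lower number from compound 1 to compound 3 (0.11 log units; within the scatter). The change from compound 1 to compound 2 is hydrogen in place of tert-butoxycarbonyl on an amine nitrogen, and it gave an at least 11-fold higher number from compound 1 to compound 2 (1.06 log units; beyond the scatter).

Compound 4, `Cc1cnc(C(=O)Nc2cc(OCCN)cc3cccnc23)cn1`, has not been measured. From compound 3 it carries the same change, (hydrogen in place of tert-butoxycarbonyl on an amine nitrogen), at the same kind of place. Because the same change gave an at least 11-fold higher number from compound 1 to compound 2 (1.06 log units; beyond the scatter), a step of about an 18-fold higher number from compound 3 to compound 4 (1.25 log units; beyond the scatter) is expected here. Compound 4 is therefore estimated at 12000 nM, most likely reported again as a limit.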

Compound 4, half-maximal inhibitory concentration: > 10000 nM
Compound 4: no number, only a limit (the forecaster's own chance of this, stated with the estimate: 70%); the middle value is on the limit's open side.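

In this assay, putting hydrogen in place of tert-butoxycarbonyl on the amine nitrogen gave an at least 14-fold higher number from compound 3 to compound 4 (1.17 log units; beyond the scatter), so the change carried over to the methyl-bearing core as a large step in the same direction. Set side by side, the two cases read: the same change on two cores in this assay, an at least 11-fold higher number (1.06 log units; beyond the scatter) from compound 1 to compound 2 and an at least 14-fold higher number (1.17 log units; beyond the scatter) from compound 3 to compound 4; the limit leaves it open whether they differ

Compound 2 and compound 4 are each reported only as a limit and not as a number, so the step between them cannot be read and the full size of each step stays unknown: the limit of > 10000 nM in this assay, at which 2 of the 4 values shown sit.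

The compounds shown leave open whether tert-butoxycarbonyl itself matters, or whether another group on that nitrogen, such as acetyl, would serve as well. They also leave open what a longer chain would give in place of 2-aminoethyl.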